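The compounds below may be only part of what the source reports. "The series", "measured", "known", "first", "only" and "open" are said of these compounds alone.

Going by the values given here, compound 2 `CC(C)[C@H](NC(=O)COc1cccc2ccccc12)C(=O)N[C@@H](CC(=O)O)C(=O)COc1c(F)c(F)cc(F)c1F` gives 4500 nM in a functional assay on Jurkat cells (Homo sapiens) (a lower number here means a stronger inhibitor, a higher number a weaker inhibitor), and this is the only true number available so far. Its close relative, compound 1 `CC(C)[C@H](NC(=O)COc1cccc2ccccc12)C(=O)N[C@@H](CC(=O)O)C(=O)COc1ccccc1F`, gives > 100000 nM, which is a limit of the assay and not a number. Among the compounds with values here, the step of an at least 22-fold lower number from compound 1 to compound 2 (1.34 log units; beyond the scatter) shows that the ring group on the oxygen can shift the result strongly, and it is the only measured step that bears on the next change. Compound 3 `CC(C)[C@H](NC(=O)COc1cccc2ccccc12)C(=O)N[C@@H](CC(=O)O)C(=O)COc1c(Cl)cccc1Cl` keeps the rest of the molecule and has 2,6-dichlorophenyl in place of 2,3,5,6-tetrafluorophenyl on that oxygen: 2,6-dichlorophenyl in place of 2,3,5,6-tetrafluorophenyl on an oxygen on a saturated carbon. With a single measured step as a guide, the forecast is uncertain, but a move towards weaker inhibition seems more likely than a gain. The expected change is a 4.4-fold higher number from compound 2 to compound 3 (0.65 log units; beyond the scatter). For compound 3 the estimated value is 20000 nM, with an expected range from 4000 nM to 100000 nM.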

Compound 3, half-maximal inhibitory concentration: 3000 nM
The estimate for compound 3 lay 6.7-fold (0.82 log units) above the measured number; measured number below the stated range.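

The step shows a 1.5-fold lower number from compound 2 to compound 3 (0.18 log units; within the scatter), so on this oxygen 2,6-dichlorophenyl and 2,3,5,6-tetrafluorophenyl cannot be told apart in this assay. The large gain over 2-fluorophenyl therefore does not depend on a ring carrying fluorine, since the chlorine-bearing ring also gives it, with an at least 33-fold lower number from compound 1 to compound 3 (1.52 log units; beyond the scatter). That step is only a minimum, since compound 1 gives a limit of the assay and not a number: the limit of > 100000 nM in this assay, at which 1 of the 3 values shown sits.

Still open, going by these compounds, is whether a ring with a single chlorine, such as 2-chlorophenyl, would stay as weak as compound 1 or match compound 2 and compound 3. On these data alone, it is also open whether the level depends on halogens at all, which 2,6-dimethylphenyl or an unsubstituted phenyl on the same oxygen would help to settle.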